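Compound 3 to compound 4: a swap on the sulfonyl sulfur

The compounds below may be only part of what the source reports. "The series", "measured", "known", "first", "only" and "open" are said of these compounds alone.

Of the compounds shown here, three have been read in an in vitro ADME assay on microsomes from liver (Rattus norvegicus) for metabolic stability, read by LC-MS, tested at 1 uM; on this read-out lower numbers stand for slow clearance and higher numbers for fast clearance. Compound 1 (`CCCS(=O)(=O)c1cccc(C#Cc2cc(Cl)ccc2OCC(=O)O)c1`) gives < 10 mL.min-1.g-1, which is a limit of the assay and not a number. Compound 2 (`CCCS(=O)(=O)c1ccc(F)c(C#Cc2cc(Cl)ccc2OCC(=O)O)c1`) gives < 10 mL.min-1.g-1, also a limit. Compound 3 (`COCCNS(=O)(=O)c1ccc(C)c(C#Cc2cc(Cl)ccc2OCC(=O)O)c1`) gives < 10 mL.min-1.g-1, again a limit, so it has no exact place on the scale, and the two further values shown are limits too. The shared picture is the limit of < 10 mL.min-1.g-1 in this assay, at which 3 of the 3 values shown sit.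

Compound 4 (`Cc1ccc(S(C)(=O)=O)cc1C#Cc1cc(Cl)ccc1OCC(=O)O`) differs from compound 3 in one place: methyl in place of (2-methoxyethyl)amino on a sulfonyl sulfur. In words, this is methyl in place of (2-methoxyethyl)amino on a sulfonyl sulfur. Among the measured compounds shown here, the only measured step is a step that the two limits leave unreadable from compound 1 to compound 2, and it concerns fluoro in place of hydrogen on an aromatic carbon, so it offers no measure for this change. For the measured compounds named here, with compound 3 held at < 10 mL.min-1.g-1, which is a limit, and no measured step on the sulfonyl sulfur, no change beyond the scatter is expected in this assay, in either direction. The estimate therefore means a step that the limit leaves unreadable from compound 3 to compound 4, an expected step and no more. For compound 4 the estimated intrinsic clearance in microsomes is 6 mL.min-1.g-1, with an expected range from 3 mL.min-1.g-1 to 12 mL.min-1.g-1.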

Compound 4, intrinsic clearance in microsomes: 18 mL.min-1.g-1
Beside the measured number, compound 4's estimate is 3.0-fold (0.48 log units) below it; the measured number lies above the stated range.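

In this assay, among the compounds shown here, methyl in place of (2-methoxyethyl)amino on a sulfonyl sulfur gives an at least 1.8-fold higher number from compound 3 to compound 4 (0.25 log units; that floor lies within the scatter), the first step that has any readable size, since the only earlier step is left unreadable by its two limits. Compound 3 stands at a limit, so this step has only a floor, and as that floor lies within the scatter, the pair does not establish a change beyond it, although it does leave open a real rise on going to methyl. Compound 4 is the one compound shown with a number rather than a limit: the limit of < 10 mL.min-1.g-1 in this assay, at which 3 of the 4 values shown sit.

A single pair cannot separate the part played by the nitrogen of the (2-methoxyethyl)sulfamoyl group from that of its chain, nor show how far the methylsulfonyl reading carries to other groups on this sulfur. An ethyl group or a plain amine there, or a dimethylamino group, could show whether the number in this assay follows the group on the sulfonyl sulfur or stays at the limit.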